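Cyanosulfanyl in Place of Bromo on the Shared Core

A few compounds are considered here, and "the series" means these few. Any claim that something is new, unique, unknown or untested is made for them only; others in the source may bear on it.

Measured compounds:
compound 1 `COc1ccc(-c2nc3sc(Cc4ccc(Cl)cc4)nn3c2Br)cc1`: 63000 nM
compound 2 `Cc1ccc(-c2nc3sc(Cc4ccc(Cl)cc4)nn3c2Br)cc1`: > 250000 nM (a limit of the assay)
compound 3 `O=[N+]([O-])c1ccc(-c2nc3sc(Cc4ccc(Cl)cc4)nn3c2Br)cc1`: 94000 nM

In a functional assay on L1210 cells (Mus musculus) for cytotoxicity, with a stated time of 48 h (a lower number here means a stronger inhibitor, a higher number a weaker inhibitor), compound 1 gives 63000 nM, the lowest of the two numbers shown. Compound 3 gives 94000 nM, and the step of a 1.5-fold higher number from compound 1 to compound 3 (0.17 log units; within the scatter) stays within the scatter. For compound 2 the assay reports only a limit, (the limit of > 250000 nM in this assay, at which 1 of the 3 values shown sits). The step of an at least 3.9-fold higher number from compound 1 to compound 2 (0.59 log units; beyond the scatter) lies beyond the scatter. Compound 4 `COc1ccc(-c2nc3sc(Cc4ccc(Cl)cc4)nn3c2SC#N)cc1` differs from compound 1 by cyanosulfanyl in place of bromo on an aromatic carbon. Going by the values given here, no measured step touches this change: each of the three exchanges the methoxy of compound 1 for methyl or nitro. With no guide, the step is expected to be no change at the digits printed from compound 1 to compound 4 (within the scatter), that is, none beyond the scatter. Compound 4 is therefore estimated at 63000 nM, within 20000 nM to 200000 nM.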

Compound 4, half-maximal inhibitory concentration: 16000 nM
Compound 4: middle estimate off by 3.9-fold (0.60 log units), on the high side, and the stated range ends above it.
By their numbers in this assay, from the lowest: compound 4; then compounds 1 and 3 (each within the scatter of the next). At a limit, above all of these: compound 2.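

The earlier compounds shown here changed only the methoxy and kept the bromo, so they said nothing about this position on the shared core. Here, in this assay, exchanging the bromo alone moves the number beyond the scatter: a 3.9-fold lower number from compound 1 to compound 4 (0.60 log units; beyond the scatter). Nothing measured here explains that step. From the compounds shown here alone, it remains open whether cyanosulfanyl in place of bromo gives a similar step when methyl or nitro replaces the methoxy. Going by these compounds, how an amine or a methylsulfanyl group would behave at this position also remains open.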